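Bromo to chloro on the aryl group of compound 2

This account rests on a few compounds, and the source may have more. Where it says the series, first, only, none or still open, it means among the compounds named here.

Measured so far:
compound 1, `CC(=O)c1cc2ccc(OCCCn3cc(CNC(=O)CCCCC4CCSS4)nn3)cc2oc1=O`, 37.5%
compound 2, `O=C(CCCCC1CCSS1)NCc1cn(CCCOc2ccc3cc(-c4ccc(Br)cc4)c(=O)oc3c2)nn1`, 57.3%

In a functional assay on PC-12 cells (Rattus norvegicus) for cytotoxicity, read by MTT assay, with stated times of 3 h and 2 h, tested at 5 uM (on this read-out lower numbers stand for a weaker effect and higher numbers for a stronger effect at the one concentration tested), compound 2 stands highest of the two numbers; its nearest neighbour is compound 1, and the step of a number 19.8 percentage points higher from compound 1 to compound 2 (beyond the scatter) lies beyond the scatter. Compound 3, `O=C(CCCCC1CCSS1)NCc1cn(CCCOc2ccc3cc(-c4ccc(Cl)cc4)c(=O)oc3c2)nn1`, differs from compound 2 by chloro in place of bromo on an aromatic carbon. Among the measured compounds shown here, no measured step concerns a bromo-to-chloro exchange; the only step known, a number 19.8 percentage points higher from compound 1 to compound 2 (beyond the scatter), is a different change and does not bear on it. Compound 3 is therefore expected to stay close to compound 2, the expected step of a number 3.3 percentage points lower from compound 2 to compound 3 (within the scatter) being within the scatter. The estimate for compound 3 is 54%, ranging from 38% to 68%.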

Compound 3, a percentage reported as activity, at one concentration (the size of the read-out at that concentration, not a potency): 60.6%
Compound 3: the middle estimate sits 6.6 percentage points below what was measured; the range from low to high includes it.
By their numbers in this assay, from the lowest: compound 1; then compounds 2 and 3 (each within the scatter of the next).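

In this assay, chloro in place of bromo on the aryl group gives a number 3.3 percentage points higher from compound 2 to compound 3 (within the scatter), so this pair does not separate the two halogens at this position. The step from acetyl also recurs with a second aryl group: 4-chlorophenyl in place of acetyl gives a number 23.1 percentage points higher from compound 1 to compound 3 (beyond the scatter), as 4-bromophenyl did before it. Nothing measured here explains either step. The compounds shown leave open whether a halogen is needed at all at this position. A plain phenyl, or a 4-methoxyphenyl or 4-aminophenyl group, would test that.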